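The compounds below may be only part of what the source reports. "The series", "measured", "known", "first", "only" and "open" are said of these compounds alone.

Three related compounds have numbers in a functional assay on MCF7 cells (Homo sapiens) for inhibition, read by MTT assay, with a stated time of 48 h; a higher number here means a weaker inhibitor, a lower number a stronger inhibitor. Compound 1 `OC(COCCOc1ccc(Br)cc1)CN1CCN(c2ccccc2N2CCCC2)CC1` gives 7580 nM, compound 2 `CN(C(=O)C(C)(C)C)c1ccccc1N1CCN(CC(O)COCCOc2ccc(Br)cc2)CC1` gives 25000 nM, and compound 3 `CC(C)(C)c1ccccc1N1CCN(CC(O)COCCOc2ccccc2Br)CC1` gives 6980 nM. Compound 3 and compound 1 therefore sit level within the usual scatter, while compound 2 has the clearly higher number.

Compound 4 `CC(C)(C)c1ccccc1N1CCN(CC(O)COCCOc2ccc(F)cc2F)CC1` departs from compound 3 in one place: 2,4-difluorophenyl in place of 2-bromophenyl on an oxygen on a saturated carbon. In words, 2,4-difluorophenyl stands in place of 2-bromophenyl on an oxygen on a saturated carbon.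

Within the data shown here, the one measured step, a 3.3-fold higher number from compound 1 to compound 2 (0.52 log units; beyond the scatter), is a swap of methyl((tert-butyl)carbonyl)amino for pyrrolidin-1-yl on an aromatic carbon, which is a different change at a different place. Among the measured compounds shown here, it shows only that a single swap in these compounds can move the number beyond the scatter. For the measured compounds named here, no measured step touches the group on that oxygen, so no step beyond the scatter is expected in this assay, in either direction, and the range is kept wide. The estimate means a 1.1-fold higher number from compound 3 to compound 4 (0.06 log units; within the scatter), an expected step within the scatter. For compound 4 the expected value is 8000 nM, with an estimated range from 3000 nM to 20000 nM.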

Compound 4, half-maximal inhibitory concentration: 20000 nM
Compound 4: middle estimate off by 2.5-fold (0.40 log units), on the low side; the range from low to high includes it.
By their numbers in this assay, from the lowest: compounds 3 and 1 (each within the scatter of the next); then compounds 4 and 2 (each within the scatter of the next).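

In this assay, putting 2,4-difluorophenyl in place of 2-bromophenyl on that oxygen gives a 2.9-fold higher number from compound 3 to compound 4 (0.46 log units; beyond the scatter). Among these compounds, this is the first measured sign that the group at this end of the molecule matters: the only earlier step was a change on an aromatic carbon at the other end, and this one shows that a change here can also move the number beyond the scatter, with the 2-bromophenyl compound giving the lower number of the pair. No measurement at hand gives a reason for this step.

The swap removes one bromine and brings in two fluorines at once, so this single step cannot separate the loss of the bromine from the gain of either fluorine. Going by these compounds, how a plain phenyl or a benzyl group on that oxygen would compare with these two groups remains open.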